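Naphthalen-2-yl for 4-phenylphenyl: notes on compound 4

A few compounds are considered here, and "the series" means these few. Any claim that something is new, unique, unknown or untested is made for them only; others in the source may bear on it.

In a functional assay on HCT-116 cells (Homo sapiens) for inhibition, read by MTT assay, with a stated time of 72 h (a lower number here means a stronger inhibitor, a higher number a weaker inhibitor), compound 1 (`O=C1/C(=C\c2ccccc2)c2c(ncn2COCc2ccccc2)CCN1Cc1ccc(-c2ccccc2)cc1`) gives 14000 nM. This lies within the scatter of compound 2 (`COc1cc(/C=C2\C(=O)N(Cc3ccccc3)CCc3ncn(COCc4ccccc4)c32)cc(OC)c1OC`) at 8900 nM, while compound 3 (`O=C1/C(=C\c2ccncc2)c2c(ncn2COCc2ccccc2)CCN1Cc1ccccc1`) gives 67100 nM, beyond the scatter of both. Compound 1 therefore stands with compound 2 at the low end of the three numbers.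

Compound 4 (`O=C1/C(=C\c2ccccc2)c2c(ncn2COCc2ccccc2)CCN1Cc1ccc2ccccc2c1`) keeps the core of compound 1 and changes one group: naphthalen-2-yl in place of 4-phenylphenyl on a saturated chain carbon bound to an amide-type nitrogen in a ring. That is naphthalen-2-yl in place of 4-phenylphenyl on a saturated chain carbon bound to an amide-type nitrogen in a ring.

Among the compounds with values here, no measured step covers this place. Within the data shown here, the only step available is a 7.5-fold higher number from compound 2 to compound 3 (0.88 log units; beyond the scatter), a modest one, for pyridin-4-yl in place of 3,4,5-trimethoxyphenyl on a double-bonded chain carbon bound to a double-bonded ring carbon. It bears only indirectly, showing that one group change in this series has moved the number beyond the scatter, so the range is kept wide.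

In this assay no step beyond the scatter is expected, and no firm direction. The estimated step is a 1.2-fold lower number from compound 1 to compound 4 (0.07 log units; within the scatter). For compound 4 the estimated value is 12000 nM, with an expected range from 5000 nM to 30000 nM.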

Compound 4, half-maximal inhibitory concentration: 19400 nM
For compound 4 the middle estimate is 1.6-fold (0.21 log units) below the measured one; measured number inside the range.
By their numbers in this assay, from the lowest: compounds 2, 1 and 4 (each within the scatter of the next, the first and the last beyond it); then compound 3.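

In this assay, within the data shown here, a 1.4-fold higher number from compound 1 to compound 4 (0.14 log units; within the scatter) is the first measured step at this position, on a saturated chain carbon bound to an amide-type nitrogen in a ring, and it leaves naphthalen-2-yl and 4-phenylphenyl indistinguishable in this assay. With both groups holding 2 six-membered aromatic rings of carbon only, going from the 4-phenylphenyl arrangement to the naphthalen-2-yl one does not move the number beyond the scatter, so this pair gives no sign that the assay separates these two groups at this place. No supporting measurement is available to account for this result.

Both groups at this position consist of carbon only, so the compounds shown leave open how the number responds to a group carrying an amine or a carboxylic acid on those aromatic rings, or to a longer chain between the ring nitrogen and the aromatic group. Going by these compounds, it also stays open whether the same pairing reads alike when 3,4,5-trimethoxyphenyl or pyridin-4-yl stands on the double-bonded chain carbon in place of the phenyl group of compound 1 and compound 4.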